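Side-chain change on the shared core, compound 1 to compound 4

The source may report more compounds than this note shows. Statements on the series, on what has been measured and on what is new or still open speak of the compounds shown alone.

In a functional assay on HepG2 cells (Homo sapiens) for inhibition, read by MTT assay, with a stated time of 48 h (a higher number here means a weaker inhibitor, a lower number a stronger inhibitor), compound 1 (`COc1ccc(N(C)c2nc(C)nc3ccccc23)cc1C(=O)NCC[Se]C#N`) gives 179 nM, the middle of three numbers. Compound 2 (`COc1ccc(N(C)c2nc(C)nc3ccccc23)cc1C(=O)OCCCCC[Se]C#N`) gives 667 nM, and compound 3 (`C[Se]c1ccc(N(C)c2nc(C)nc3ccccc23)cc1C`) gives 6 nM. Compound 4 (`COc1ccc(N(C)c2nc(C)nc3ccccc23)cc1OCCCCC[Se]C#N`) is still unmeasured, and its change from compound 1 is a group of 9 heavy atoms (6 carbon, 1 nitrogen, 1 oxygen, 1 selenium; no ring) in place of a group of 8 heavy atoms (4 carbon, 2 nitrogen, 1 oxygen, 1 selenium; no ring), on an aromatic carbon. For the measured compounds named here, the one measured step bearing on this is a 3.7-fold higher number from compound 1 to compound 2 (0.57 log units; beyond the scatter). That step also removes the amide hydrogen, but compound 2 keeps its carbonyl and compound 4 does not, so it is only a loose guide. A move to a higher number of similar or smaller size is therefore expected in this assay. The expected step is a 2.2-fold higher number from compound 1 to compound 4 (0.35 log units; beyond the scatter). Compound 4 is estimated at 400 nM, with an expected range of 120 nM to 1300 nM.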

Compound 4, half-maximal inhibitory concentration: 5210 nM
Estimate against measurement, compound 4: 13-fold (1.11 log units) below; the whole stated range lies below it.
By their numbers in this assay, from the lowest: compound 3; then compound 1; then compound 2; then compound 4.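

In this assay, replacing the amide side chain on this aromatic carbon gives a 29-fold higher number from compound 1 to compound 4 (1.46 log units; beyond the scatter), a much larger step than a 3.7-fold higher number from compound 1 to compound 2 (0.57 log units; beyond the scatter). Compound 2 and compound 4 differ only in the carbonyl, with compound 2 at 667 nM and compound 4 at 5210 nM, so the carbonyl matters here, not chain length alone. No available data explain this difference. The step from compound 1 changes both the link and the chain, so their shares remain unseparated. From the compounds shown here alone, an ether with a shorter chain, or an amine link, remains open.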